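The source may hold more compounds than are shown below. What is called first, only, known or untested is meant among the compounds shown, and "the series" means these compounds.

Measured compounds:
compound 1, `CC(C)N[C@H](C(=O)Nc1cc2cc[nH]c(=O)c2cc1Cl)C1CCCCC1`, 25 nM
compound 2, `N[C@H](C(=O)Nc1cc2cc[nH]c(=O)c2cc1Cl)C1CCCCC1`, 20 nM

In an assay on isolated protein for inhibition of Rho-associated protein kinase 2 (Homo sapiens) (a higher number here means a weaker inhibitor, a lower number a stronger inhibitor), compound 1 gives 25 nM, and in this assay compound 2 gives 20 nM. Among the measured compounds shown here, the one step between them, a 1.3-fold lower number from compound 1 to compound 2 (0.10 log units; within the scatter), shows hydrogen in place of isopropyl on an amine nitrogen and leaves the two numbers within the scatter, so compound 2 stands together with compound 1 rather than apart from it.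

Compound 3, `N[C@@H](C(=O)Nc1cc2cc[nH]c(=O)c2cc1Cl)C1CCCCC1`, has not yet been measured in this assay. the two compounds have the same atoms and bonds and differ only in configuration as drawn: 1 of 1 stereo elements differ; a stereocentre at a saturated chain carbon is drawn S in compound 2 and R in compound 3

For the measured compounds named here, no measured step speaks to a change of this kind: the only step in hand, a 1.3-fold lower number from compound 1 to compound 2 (0.10 log units; within the scatter), concerns the group on the amine nitrogen and was within the scatter. The data therefore give no number to rest on for the step from compound 2 to compound 3, and the expectation below is correspondingly uncertain. For compound 3 the expected step in this assay is a 10-fold higher number from compound 2 to compound 3 (1.00 log units; beyond the scatter), and the estimate for compound 3 is 200 nM, within a range from 25 nM to 3000 nM.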

Compound 3, half-maximal inhibitory concentration: 400 nM
The estimate for compound 3 lay 2.0-fold (0.30 log units) below the measured number; low and high end bracket the measured number.
By their numbers in this assay, from the lowest: compounds 2 and 1 (each within the scatter of the next); then compound 3.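

In this assay, among the compounds shown here, the change of configuration gives a 20-fold higher number from compound 2 to compound 3 (1.30 log units; beyond the scatter), a large step, whereas the only earlier step, a 1.3-fold lower number from compound 1 to compound 2 (0.10 log units; within the scatter), stayed within the scatter. The whole of the new step can be assigned to the stereocentre at the saturated chain carbon, because nothing else separates the pair: the fact that compounds 2 and 3 differ only in the configuration as drawn. For this pair, then, the configuration as drawn at that carbon counts for far more in this assay than the exchange of isopropyl for hydrogen on the amine nitrogen did in the earlier pair, with the S form, compound 2, giving the lower number.

The compounds shown leave open whether the R configuration would bring a step of the same size with isopropyl on the amine nitrogen, since the one measured change of configuration carries a free amine in both compounds. They also leave open how a methyl group or a longer chain on that nitrogen would read in either configuration, and what lies behind the difference between the two forms.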